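Aryl swap on the ring amine nitrogen: compound 4

The compounds below may be only part of what the source reports. "The series", "measured", "known", "first", "only" and "open" are said of these compounds alone.

Compound 1 `Nc1scc(CN2CCN(c3ccc(Cl)cc3Cl)CC2)c1C(=O)c1ccc(Cl)cc1` is one of three close analogues measured in an assay on CHO cells for displacement of a labelled ligand from adenosine receptor A1 (Homo sapiens), read by scintillation counting, with a stated time of 120 min, tested at 10 uM; on this read-out lower numbers stand for less inhibition and higher numbers for more inhibition at the one concentration tested (going by the name of the read-out). In this assay compound 1 gives 0%, the lowest of the three numbers, although compound 2 `Nc1scc(CN2CCN(c3cccc(Cl)c3Cl)CC2)c1C(=O)c1ccc(Cl)cc1` with 2% and compound 3 `Nc1scc(CN2CCN(c3cc(Cl)cc(Cl)c3)CC2)c1C(=O)c1ccc(Cl)cc1` with 1% both sit within the scatter of it: a number 2 percentage points higher from compound 1 to compound 2 (within the scatter) and a number 1 percentage points higher from compound 1 to compound 3 (within the scatter). Compound 4 `COc1ccc(N2CCN(Cc3csc(N)c3C(=O)c3ccc(Cl)cc3)CC2)cc1` differs from compound 1 by 4-methoxyphenyl in place of 2,4-dichlorophenyl on an amine nitrogen in a ring. Among the compounds with values here, no measured step bears on this change directly; the two steps that exchange one dichlorophenyl for another dichlorophenyl at the same ring nitrogen stayed within the scatter. Compound 4 is therefore expected to show essentially no inhibition in this assay, an estimated 3% within 0% to 15%, so that the expected step of a number 3 percentage points higher from compound 1 to compound 4 (within the scatter) lies within the scatter.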

Compound 4, a percentage reported as inhibition, at one concentration (the size of the read-out at that concentration, not a potency): 0%
Beside the measured number, compound 4's estimate is 3 percentage points above it, and the stated range covers the measured number.
By their numbers in this assay, from the lowest: compounds 1, 4, 3 and 2 (each within the scatter of the next).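

In this assay the 4-methoxyphenyl group on this ring nitrogen reads level with all three dichlorophenyl analogues: no change at the digits printed from compound 1 to compound 4 (within the scatter), a number 1 percentage points lower from compound 3 to compound 4 (within the scatter) and a number 2 percentage points lower from compound 2 to compound 4 (within the scatter). Not only moving the chlorines but replacing them with a methoxy group, which adds a hydrogen-bond acceptor, leaves the read-out within the scatter. Nothing available accounts for these flat numbers.

On these data alone, whether a non-aryl group on this nitrogen, such as a carboxylic acid or a longer chain bearing an amine, would give measurable inhibition stays open. Also open, as far as these compounds go, is whether changes elsewhere on the shared core would do so.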